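The source may report more compounds than this note shows. Statements on the series, on what has been measured and on what is new or still open speak of the compounds shown alone.

Working notes on the series

Compound 1 `O=C(/C=C\Nc1ccc(Cl)cc1)c1cn(-c2ccccc2)nc1-c1ccccc1` carries a chloro group on the aniline ring; in a functional assay on PC-3 cells (Homo sapiens) for antiproliferative activity, read by MTT assay, with a stated time of 48 h (on this read-out lower numbers stand for stronger inhibition and higher numbers for weaker inhibition), compound 1 gives 5200 nM. Compound 2 `O=C(/C=C\Nc1ccc(C(F)(F)F)cc1)c1cn(-c2ccccc2)nc1-c1ccccc1` differs from compound 1 by trifluoromethyl in place of chloro on an aromatic carbon. For compound 2 the read-out in this assay is a limit, > 50000 nM, and not a number, as noted in the limit of > 50000 nM in this assay, at which 1 of the 3 values shown sits. The step of an at least 9.6-fold higher number from compound 1 to compound 2 (0.98 log units; beyond the scatter) is therefore known only as a lower bound. Compound 3 `COc1ccc(-c2nn(-c3ccccc3)cc2C(=O)/C=C\Nc2ccc(Cl)cc2)cc1` differs from compound 1 in its core by methoxy in place of hydrogen on an aromatic carbon; in this assay compound 3 gives 3890 nM, and the step of a 1.3-fold lower number from compound 1 to compound 3 (0.13 log units; within the scatter) does not separate the two compounds.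

Compound 4 `COc1ccc(-c2nn(-c3ccccc3)cc2C(=O)/C=C\Nc2ccc(C(F)(F)F)cc2)cc1` is not yet measured. It differs from compound 3 by trifluoromethyl in place of chloro on an aromatic carbon, the same change that carries compound 1 to compound 2, at a place described in the same words. For compound 4 a step of a 10-fold higher number from compound 3 to compound 4 (1.01 log units; beyond the scatter) is expected, resting on the size of an at least 9.6-fold higher number from compound 1 to compound 2 (0.98 log units; beyond the scatter) seen for compound 1. Compound 4 is accordingly estimated at 40000 nM, with a range from 15000 nM to 120000 nM and a substantial chance that only a limit is reported.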

Compound 4, half-maximal inhibitory concentration: > 50000 nM
Compound 4: a limit, no number; the forecaster's own chance of this, stated with the estimate: 60%; at least 1.2-fold (0.09 log units) between middle value and limit.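

In this assay trifluoromethyl in place of chloro gives a higher number on the core of compound 3 as well (with an at least 12-fold higher number from compound 3 to compound 4 (1.10 log units; beyond the scatter)), so the direction seen on the core of compound 1 carries over to this second core: the same change on two cores in this assay, an at least 9.6-fold higher number (0.98 log units; beyond the scatter) from compound 1 to compound 2 and an at least 12-fold higher number (1.10 log units; beyond the scatter) from compound 3 to compound 4; the limit leaves it open whether they differ.

This does not show that the step has the same size on both cores, and the step between compound 2 and compound 4 cannot be read, since both compounds stand at a limit: the limit of > 50000 nM in this assay, at which 2 of the 4 values shown sit.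

The pattern rests on these two pairs only, and neither goes against it.

The compounds shown leave open how far past the limit compound 2 and compound 4 truly lie. They also leave open where an amine, a nitrile or a carboxylic acid would fall on the same aromatic carbon, on either core, relative to chloro and trifluoromethyl.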